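Replacing a Pyridyl Amide with an Acylhydrazide on a Shared Core

This account rests on a few compounds, and the source may have more. Where it says the series, first, only, none or still open, it means among the compounds named here.

Of the compounds shown here, three built on one shared core have been measured in a physicochemical assay for lipophilicity, read by HPLC, in phosphate buffer, measured as chromatographic lipophilicity, at pH 7.4; a lower number here means a more polar compound, a higher number a more lipophilic compound. Compound 1 `COc1ccc2nc(C)cc(OCC(=O)NCc3cc(C)cc(C)c3)c2c1` gives 5.25. Compound 2 `COc1ccc2nc(C)cc(OCC(=O)Nc3ccccn3)c2c1` gives 3.49, and compound 3 `COc1ccc2nc(C)cc(OCC(=O)Nc3cccnc3)c2c1` gives 2.46. Every change so far has been made to the group on the amide-type nitrogen: a number 1.76 log units lower from compound 1 to compound 2 (beyond the scatter), a number 2.79 log units lower from compound 1 to compound 3 (beyond the scatter) and a number 1.03 log units lower from compound 2 to compound 3 (beyond the scatter). Compound 3 therefore stands lowest of the three numbers, with compound 2 nearest and compound 1 furthest away.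

Compound 4 `COc1ccc2nc(C)cc(OCC(=O)NNC(=O)c3ccncc3)c2c1` continues this series at the same position. ((pyridin-4-yl)carbonyl)amino in place of pyridin-3-yl on an amide-type nitrogen The entering group is larger than the one it replaces and brings a hydrogen-bond donor where the leaving group had none. All three measured steps bear on this change, since each swapped the group on the amide-type nitrogen, and each moved the number well beyond the scatter; even exchanging one pyridyl for another gave a step beyond the scatter. A further downward step is therefore expected, estimated at a number 0.66 log units lower from compound 3 to compound 4 (beyond the scatter). For compound 4 the estimate in this assay is 1.8, with a likely range from 1 to 2.6.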

Compound 4, distribution coefficient: 1.48
Compound 4: the middle estimate sits 0.32 log units above what was measured; the range from low to high includes it.
By their numbers in this assay, from the lowest: compound 4; then compound 3; then compound 2; then compound 1.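

In this assay the ((pyridin-4-yl)carbonyl)amino group brings a number 0.98 log units lower from compound 3 to compound 4 (beyond the scatter) as a modest step, a number 2.01 log units lower from compound 2 to compound 4 (beyond the scatter) as a large one and a number 3.77 log units lower from compound 1 to compound 4 (beyond the scatter) as the largest of the three, so compound 4 now stands lowest of the four. Before this result, the lowest numbers belonged to the two compounds with a pyridine ring attached directly to the amide-type nitrogen, and the smaller pyridyl groups stood below the 3,5-dimethylbenzyl group of compound 1. Compound 4 goes against any reading of that order as simple size: its entering group is larger than pyridin-3-yl and brings a hydrogen-bond donor, yet its number is lower than that of compound 3, and no measurement here explains this.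

The carbonyl, the added nitrogen and the pyridin-4-yl ring all change at once, so the compounds shown leave open which of these parts carries the step. A plain benzoyl group or an acetyl group on that same nitrogen would begin to separate those parts.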